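Adding a methoxy to the anilino group of compound 1

The compounds below may be only part of what the source reports. "The series", "measured", "known", "first", "only" and "open" are said of these compounds alone.

Measured so far:
compound 1 `COc1ccc(C(=O)c2sc(Nc3ccccc3)nc2N)cc1OC` gives 6000 nM in a functional assay on HeLa cells (Homo sapiens) for antiproliferative activity, read by cell counting, with a stated time of 2 days; on this read-out lower numbers stand for stronger inhibition and higher numbers for weaker inhibition;
compound 2 `COc1cccc(C(=O)c2sc(Nc3ccccc3)nc2N)c1` gives 1700 nM in this assay.

Within the data shown here, compound 1 stands at the highest of the two numbers measured so far; compound 2 sits below it by a 3.5-fold lower number from compound 1 to compound 2 (0.55 log units; beyond the scatter), a step that comes from hydrogen in place of methoxy on an aromatic carbon. The unmeasured compound 3 `COc1ccc(Nc2nc(N)c(C(=O)c3ccc(OC)c(OC)c3)s2)cc1` differs from compound 1 by methoxy in place of hydrogen on an aromatic carbon; put one bond further out, this reads phenyl to 4-methoxyphenyl, or anilino to (4-methoxyphenyl)amino.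

Among the measured compounds shown here, only one measured step exists, and it concerns a different methoxy from the one that enters here, so it tells little about the change in hand; no measured step bears directly on it. In the absence of such evidence the safest expectation is a step no larger than the scatter in this assay, with no clear direction. Compound 3 is therefore estimated at 6000 nM, within 2500 nM to 14000 nM, which corresponds to an expected step of no change at the digits printed from compound 1 to compound 3 (within the scatter).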

Compound 3, half-maximal inhibitory concentration: 52 nM
Compound 3: middle estimate off by 120-fold (2.06 log units), on the high side; measured number outside the range, below it.
By their numbers in this assay, from the lowest: compound 3; then compound 2; then compound 1.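

The anilino group, bare in both earlier compounds, proves to be a highly sensitive place: in this assay, the change from phenyl to 4-methoxyphenyl brings a 120-fold lower number from compound 1 to compound 3 (2.06 log units; beyond the scatter). Among these compounds, the only earlier step, a 3.5-fold lower number from compound 1 to compound 2 (0.55 log units; beyond the scatter), involved a different methoxy and was much smaller, and there it was the loss of the methoxy that lowered the number, whereas here it is the gain of one. Methoxy therefore has no single effect across these compounds, and what it does depends on where it sits, at least in the two places compared; nothing available here explains why this one matters so much.

On these data alone, it remains open whether the methoxy itself is needed at this place, or whether another group there, such as a methyl, a chlorine, an ethoxy or an amine, would lower the number as far. Also unresolved is whether the same methoxy would have a similar effect on another carbon of the anilino ring, or when added to the anilino group of compound 2, which has one methoxy fewer on its other aromatic ring.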